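Swapping a pyridine for a fluorophenyl on a weak cytotoxic scaffold

The compounds below may be only part of what the source reports. "The series", "measured", "known", "first", "only" and "open" are said of these compounds alone.

Measured compounds:
- compound 1 `O[C@@H](c1ccccc1)[C@H]1CO[C@H](c2ccccc2)[C@@H](C/C=C/c2ccccn2)C1`: 33800 nM
- compound 2 `COc1cccc(/C=C/C[C@@H]2C[C@@H]([C@@H](O)c3ccc(OC)c(OC)c3)CO[C@H]2c2ccc(OC)c(OC)c2)c1`: 16400 nM
- compound 3 `COc1ccc(/C=C/C[C@@H]2C[C@@H]([C@@H](O)c3ccc(OC)c(OC)c3)CO[C@H]2c2ccccc2)cc1OC`: 16100 nM

The three compounds were tested in a functional assay on HeLa cells (Homo sapiens) for cytotoxicity, read by WST assay, with a stated time of 48 h; on this read-out higher numbers stand for weaker inhibition and lower numbers for stronger inhibition. Compound 1 has the highest number of the three, so it is the weakest of them; compound 2 and compound 3 both sit below it, and both gaps lie beyond the scatter of repeated measurements. Compound 2 and compound 3 sit within the scatter of each other.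

Compound 4 `O[C@@H](c1ccccc1)[C@H]1CO[C@H](c2ccccc2)[C@@H](C/C=C/c2cccc(F)c2)C1` has not been measured. It differs from compound 1 in one place: 3-fluorophenyl in place of pyridin-2-yl on a double-bonded chain carbon bound to a double-bonded chain carbon. In compound 2 and compound 3 the chain also ends in a carbon-only aromatic ring rather than a pyridine, and those two compounds give lower numbers than compound 1, though they carry other changes as well, so no clean comparison exists.

On that basis a small downward step is expected, a 1.4-fold lower number from compound 1 to compound 4 (0.15 log units; within the scatter), near the edge of the scatter. Compound 4 is therefore estimated at 24000 nM, with a range from 10000 nM to 60000 nM.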

Compound 4, half-maximal inhibitory concentration: 8380 nM
For compound 4 the middle estimate is 2.9-fold (0.46 log units) above the measured one, and the stated range ends above it.
By their numbers in this assay, from the lowest: compounds 4, 3 and 2 (each within the scatter of the next); then compound 1.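

In this assay the swap to 3-fluorophenyl from pyridin-2-yl, on a double-bonded chain carbon bound to a double-bonded chain carbon, gives a 4.0-fold lower number from compound 1 to compound 4 (0.61 log units; beyond the scatter) and counts as a modest step. Compound 2 and compound 3 differ from compound 1 in several places at once, whereas compound 1 and compound 4 differ in this one place, so this pair shows that the aromatic group at the end of the chain can shift the number by itself, with the rest of the molecule unchanged. No measurement shown here gives a reason for the shift.

This single swap removes the ring nitrogen and adds the fluorine together, so the compounds shown cannot tell which of the two changes matters. A plain phenyl at the same place would separate them, and a chlorophenyl would show whether another halogen behaves like fluorine.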